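Adding a hydroxy group to a quinoline-free-named shared core

The source may report more compounds than this note shows. Statements on the series, on what has been measured and on what is new or still open speak of the compounds shown alone.

Two compounds in this series carry numbers in an ADME assay on CCD 19Lu cells (Homo sapiens) for antiproliferative activity, read by MTT assay, with a stated time of 24 h; a lower number here means a stronger inhibitor, a higher number a weaker inhibitor. Compound 1 `Clc1ccc(-c2cc(-c3ccccc3)c3cc(Br)ccc3n2)cc1` gives 528000 nM, and compound 2 `Brc1ccc2nc(-c3ccccc3)cc(-c3ccccc3)c2c1` gives 669000 nM. Compound 2 stands highest of the two numbers, with compound 1 as its nearest neighbour, and the step of a 1.3-fold higher number from compound 1 to compound 2 (0.10 log units; within the scatter) lies within the scatter. For compound 3 `Fc1ccc(-c2cc(-c3ccccc3)c3cc(Br)ccc3n2)cc1` the entry in this assay reads "not determined" (no result reported), so no number is available for it. The next compound, compound 4 `Oc1ccc(-c2cc(-c3ccccc3)c3cc(Br)ccc3n2)cc1`, differs from compound 2 by hydroxy in place of hydrogen on an aromatic carbon, a change that reads as phenyl to 4-hydroxyphenyl when cut one bond further out. Among the measured compounds shown here, no measured pair bears directly on this change; the only step available, from a chloro group to hydrogen at the same position, was too small to stand out from the scatter, so there is no basis for expecting a large move in this assay from adding a hydroxy group there. The expected step of a 1.1-fold lower number from compound 2 to compound 4 (0.05 log units; within the scatter) is therefore small, and for compound 4 an estimate of 600000 nM is expected, within a range from 200000 nM to 1800000 nM.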

Compound 4, half-maximal inhibitory concentration: 104000 nM
For compound 4 the middle estimate is 5.8-fold (0.76 log units) above the measured one; the whole stated range lies above it.
By their numbers in this assay, from the lowest: compound 4; then compounds 1 and 2 (each within the scatter of the next).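

In this assay this aromatic carbon proves sensitive to what sits on it: hydroxy in place of hydrogen gives a 6.4-fold lower number from compound 2 to compound 4 (0.81 log units; beyond the scatter), a step beyond the scatter, whereas the earlier swap of chloro for hydrogen stayed within it. Hydroxy in place of chloro gives a 5.1-fold lower number from compound 1 to compound 4 (0.71 log units; beyond the scatter), so compound 4 stands apart from both earlier compounds with numbers, whichever of them it is set against. Nothing available here explains why the hydroxy group has this effect.

A methoxy group, an amine or a carboxylic acid on this same carbon would show whether the step belongs to hydroxy alone or extends to other groups. Going by these compounds, the entry for compound 3 carries no number, so its steps to the other compounds cannot be read, and the place of the fluoro group in this order stays unknown.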